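Swapping the oxazole aryl arm for a small amide

The source may report more compounds than this note shows. Statements on the series, on what has been measured and on what is new or still open speak of the compounds shown alone.

Compound 1 `COC(=O)c1ccc(-c2cnc(C(=O)CCc3ccc(-c4ccccc4)cc3)o2)nc1`: 2.2 nM
Compound 2 `O=C(O)c1cc(-c2cnc(C(=O)CCc3ccc(-c4ccccc4)cc3)o2)ccn1`: 50 nM
Compound 3 `N#Cc1cccc(-c2cnc(C(=O)CCc3ccc(-c4ccccc4)cc3)o2)n1`: 2.9 nM

In an assay for inhibition of Fatty-acid amide hydrolase 1 (Rattus norvegicus) (a lower number here means a stronger inhibitor, a higher number a weaker inhibitor), compound 3 gives 2.9 nM and sits second of the three numbers: one of its gaps is a 1.3-fold higher number from compound 1 to compound 3 (0.12 log units; within the scatter), while the other is a 17-fold lower number from compound 2 to compound 3 (1.24 log units; beyond the scatter). Compound 4 `CN(C)C(=O)c1cnc(C(=O)CCc2ccc(-c3ccccc3)cc2)o1` differs from compound 3 by dimethylcarbamoyl in place of 6-cyanopyridin-2-yl on an aromatic carbon. Among the measured compounds shown here, no measured step removes the aromatic arm outright; the steps that exist, a 23-fold higher number from compound 1 to compound 2 (1.36 log units; beyond the scatter) and a 1.3-fold higher number from compound 1 to compound 3 (0.12 log units; within the scatter), show only that a free carboxylic acid weakens binding while the two pyridyl groups behave alike. Compound 4 is therefore expected to bind somewhat more weakly than compound 3, a step estimated at a 5.2-fold higher number from compound 3 to compound 4 (0.71 log units; beyond the scatter). The estimate for compound 4 is 15 nM, between 3 nM and 80 nM.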

Compound 4, inhibition constant: 3 nM
Compound 4: middle estimate off by 5.0-fold (0.70 log units), on the high side, and the stated range covers the measured number.
By their numbers in this assay, from the lowest: compounds 1, 3 and 4 (each within the scatter of the next); then compound 2.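

Dimethylcarbamoyl, which has no ring, sits on the aromatic carbon next to the ring oxygen and cannot be told apart from the pyridyl arms in this assay: a 1.0-fold higher number from compound 3 to compound 4 (0.01 log units; within the scatter) and a 1.4-fold higher number from compound 1 to compound 4 (0.13 log units; within the scatter). The six-membered aromatic ring is therefore not required at this position for these values, while the amide still shows a 17-fold lower number from compound 2 to compound 4 (1.22 log units; beyond the scatter). No evidence here accounts for this result.

The compounds shown leave open whether a primary amide, an amine or a carboxylic acid attached directly at this carbon would give similar values.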